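Working notes on the cytotoxicity step from compound 3 to compound 4

A few compounds are considered here, and "the series" means these few. Any claim that something is new, unique, unknown or untested is made for them only; others in the source may bear on it.

Measured so far in an ADME assay on L02 cells (Homo sapiens) for cytotoxicity, read by MTT assay, with a stated time of 48 h; a lower number here means a stronger inhibitor, a higher number a weaker inhibitor:

Compound 1 `Cc1cccc(Cn2cc(COc3ccc4c(=O)ccoc4c3)nn2)c1`: > 300000 nM
Compound 2 `N#Cc1ccc(Cn2cc(COc3ccc4c(=O)ccoc4c3)nn2)cc1`: > 300000 nM
Compound 3 `O=c1ccoc2cc(OCc3cn(Cc4ccccc4Br)nn3)ccc12`: > 300000 nM

Each of these three values is a limit of the assay, not a number. Compound 3 stands at that limit. Compound 1 stands at the same limit. Compound 2 stands there as well, so all three values sit at one point (the limit of > 300000 nM in this assay, at which 3 of the 3 values shown sit). Among the measured compounds shown here, the steps a step that the two limits leave unreadable from compound 1 to compound 2, a step that the two limits leave unreadable from compound 1 to compound 3 and a step that the two limits leave unreadable from compound 2 to compound 3 are therefore all unreadable, and no step between measured compounds gives a readable size.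

Compound 4 `O=c1ccoc2cc(OCc3cn(Cc4ccc(Cl)cc4Cl)nn3)ccc12` differs from compound 3 by 2,4-dichlorophenyl in place of 2-bromophenyl on a saturated chain carbon bound to an aromatic nitrogen. With no readable step in this series to lean on, the step that the limit leaves unreadable from compound 3 to compound 4 is expected to be unreadable as well, with compound 4 most likely reported again as a limit. The estimate for compound 4 is 450000 nM, with a range from 150000 nM to 1500000 nM.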

Compound 4, half-maximal inhibitory concentration: > 300000 nM
Compound 4: a limit, no number (the forecaster's own chance of this, stated with the estimate: 85%); the middle value does not contradict the limit.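

In this assay compound 4 gives > 300000 nM as a limit, not a number. Among the compounds shown here, no step from compound 1, compound 2 or compound 3 to compound 4 can be read: the limit of > 300000 nM in this assay, at which 4 of the 4 values shown sit. In this assay the compounds shown leave open what size any of these group changes has.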